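Methoxycarbonyl in Place of Fluoro: Three Measured, One Awaited

The source may hold more compounds than are shown below. What is called first, only, known or untested is meant among the compounds shown, and "the series" means these compounds.

Compound 1 `Cc1cc(NC(=O)Nc2ccc(F)cc2)c2ccccc2n1`: > 25000 nM
Compound 2 `Cc1cc(NC(=O)Nc2cccc(F)c2)c2ccccc2n1`: > 25000 nM
Compound 3 `COC(=O)c1ccc(NC(=O)Nc2cc(C)nc3ccccc23)cc1`: 15000 nM

In an ADME assay on HEK293 cells (Homo sapiens) for cytotoxicity, with a stated time of 72 h (a lower number here means that less compound is needed, a higher number that more compound is needed for the effect), compound 1 gives > 25000 nM, a limit of the assay and not a number. Compound 2 likewise gives > 25000 nM, also a limit. Compound 2 differs from compound 1 by 3-fluorophenyl in place of 4-fluorophenyl on an amide-type nitrogen, and the step that the two limits leave unreadable from compound 1 to compound 2 cannot be read because of the limit of > 25000 nM in this assay, at which 2 of the 3 values shown sit. Compound 3 differs from compound 1 by methoxycarbonyl in place of fluoro on an aromatic carbon. In this assay compound 3 gives 15000 nM. The step is an at least 1.6-fold lower number from compound 1 to compound 3 (0.22 log units; that floor lies within the scatter), a floor only because of the limit of > 25000 nM in this assay, at which 2 of the 3 values shown sit.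

Compound 4 `COC(=O)c1cccc(NC(=O)Nc2cc(C)nc3ccccc23)c1` differs from compound 2 by methoxycarbonyl in place of fluoro on an aromatic carbon, the same kind of change, though here meta to a large group rather than para to a large group. A step of an at least 1.6-fold lower number from compound 2 to compound 4 (0.22 log units; that floor lies within the scatter) is expected, set beside an at least 1.6-fold lower number from compound 1 to compound 3 (0.22 log units; that floor lies within the scatter), resting on compound 3 at 15000 nM. Compound 4 is therefore estimated at 15000 nM, between 6000 nM and 40000 nM.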

Compound 4, half-maximal effective concentration: 26000 nM
Compound 4: middle estimate off by 1.7-fold (0.24 log units), on the low side, within the range that was stated.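

No step from compound 2 to compound 4 can be read in this assay, because the value of compound 2 is a limit and not a number: the limit of > 25000 nM in this assay, at which 2 of the 4 values shown sit.

The compounds shown leave open how large the change is when methoxycarbonyl replaces fluoro meta to a large group.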